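The source may report more compounds than this note shows. Statements on the series, on what has been measured and on what is new or still open speak of the compounds shown alone.

Measured in a functional assay on HCT-116 cells (Homo sapiens) for inhibition, read by MTT assay, with a stated time of 2 days, tested at 10 uM; on this read-out lower numbers stand for less inhibition and higher numbers for more inhibition at the one concentration tested (going by the name of the read-out):

- compound 1 `COC(=O)c1cc(-n2cc(-c3cccc(O)c3)nn2)ccc1O`: 6%
- compound 2 `O=C(OCCCc1ccccc1)c1cc(-n2cc(-c3cccc(O)c3)nn2)ccc1O`: 11%
- compound 3 `COC(=O)c1cc(-n2cc(-c3cc(OC)cc(OC)c3)nn2)ccc1O`: 3%

Compound 2 has the highest of the three numbers, but its nearest neighbour, compound 1, sits a number 5 percentage points higher from compound 1 to compound 2 (within the scatter), and compound 3 is also within the scatter of it, so the three compounds cannot be told apart by these readings. All three sit at the low end of the read-out.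

The new compound, compound 4 `COc1ccc(-c2cn(-c3ccc(O)c(C(=O)OCCCc4ccccc4)c3)nn2)cc1`, is reached from compound 2 by one change: 4-methoxyphenyl in place of 3-hydroxyphenyl on an aromatic carbon. For the measured compounds named here, no measured step covers this kind of change. Going by the values given here, the only measured step, a number 5 percentage points higher from compound 1 to compound 2 (within the scatter), concerns the ester chain, which compound 4 keeps unchanged from compound 2. Compound 1 and compound 3 differ at the same aromatic ring, yet no step between them is shown; compound 1 gives 6% and compound 3 gives 3%, both low numbers. Nothing here points to a swing beyond the scatter, so compound 4 is expected to change by about a number 2 percentage points lower from compound 2 to compound 4 (within the scatter), which is no step beyond the scatter. Compound 4 is therefore estimated at 9%, with a range from 0% to 22%.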

Compound 4, a percentage reported as inhibition, at one concentration (the size of the read-out at that concentration, not a potency): 12%
The estimate for compound 4 lay 3 percentage points below the measured number; low and high end bracket the measured number.
By their numbers in this assay, from the lowest: compounds 3, 1, 2 and 4 (each within the scatter of the next).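

This is the first step shown at this position, on the aromatic carbon of the five-membered ring with 3 nitrogen, and in this assay it reads as a number 1 percentage points higher from compound 2 to compound 4 (within the scatter). The entering 4-methoxyphenyl has 0 hydrogen-bond donors against 1 for the leaving 3-hydroxyphenyl, and 8 heavy atoms against 7, yet for this single pair, with the ester chain held constant, these differences come with no change beyond the scatter. No measurement shown gives a reason for this reading.

The compounds shown leave open whether any group at this position can move the number in this assay beyond the scatter, since all the groups here are phenyl rings carrying hydroxyl or methoxy, and a phenyl ring bearing an amine or a carboxylic acid could behave differently. They also leave open whether 4-methoxyphenyl in place of 3-hydroxyphenyl would read the same on the shorter ester of compound 1, as this one step comes from a single ester chain.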